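Notes on a trifluoromethyl analogue in a weakly active series

The compounds below may be only part of what the source reports. "The series", "measured", "known", "first", "only" and "open" are said of these compounds alone.

Measured compounds in an assay on isolated protein for inhibition of Dipeptidyl peptidase 9 (Homo sapiens), read by fluorescence, with a stated time of 20 min; a lower number here means a stronger inhibitor, a higher number a weaker inhibitor:
Compound 1, `N#Cc1ccccc1Cn1c(N2CCC[C@@H](N)C2)nc2sccc2c1=O`, gives > 25000 nM, a limit of this assay rather than a number.
Compound 2, `Cc1csc2nc(N3CCC[C@@H](N)C3)n(Cc3ccccc3C#N)c(=O)c12`, gives > 25000 nM, also a limit.

Compound 2 thus stands at the limit of > 25000 nM in this assay, at which 2 of the 2 values shown sit; its value is a limit only. Among the compounds with values here, the single measured step, a step that the two limits leave unreadable from compound 1 to compound 2, runs between two limits and has no readable size. Compound 3, `N#Cc1ccccc1Cn1c(N2CCC[C@@H](N)C2)nc2scc(C(F)(F)F)c2c1=O`, differs from compound 2 by trifluoromethyl in place of methyl on an aromatic carbon. Within the data shown here, no measured step bears on this change, and the two limits give no direction; nothing beyond the scatter can be read. Compound 3 is expected to stay near the same limit, with the step estimated at a step that the limit leaves unreadable from compound 2 to compound 3. The estimate for compound 3 in this assay is 30000 nM, ranging from 12000 nM to 100000 nM.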

Compound 3, half-maximal inhibitory concentration: > 25000 nM
Compound 3 gave a limit, no number; the forecaster's own chance of this, stated with the estimate: 85%; the middle value does not contradict the limit.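

Within the data shown here, compound 1, compound 2 and compound 3 all give limits, not numbers, so no step among them can be read: the limit of > 25000 nM in this assay, at which 3 of the 3 values shown sit. The compounds shown leave open whether hydrogen, methyl or trifluoromethyl on that aromatic carbon makes any difference to inhibition.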